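Swapping naphthalen-1-yl for methyl in compound 4

The source may hold more compounds than are shown below. What is called first, only, known or untested is meant among the compounds shown, and "the series" means these compounds.

Measured in a functional assay on AGS cells (Homo sapiens) for cytotoxicity, read by MTT assay, with a stated time of 48 h; on this read-out higher numbers stand for weaker inhibition and lower numbers for stronger inhibition:
compound 1 `Cc1nc2c3ccccc3ccc2c2nc3c(ccc4ccccc43)c(-c3cccc([N+](=O)[O-])c3)c12` gives 25500 nM
compound 2 `Cc1nc2c3ccccc3ccc2c2nc3c(ccc4ccccc43)c(-c3cccc4ccccc34)c12` gives 12100 nM
compound 3 `Cc1nc2c3ccccc3ccc2c2nc3c(ccc4ccccc43)c(-c3ccc(O)cc3)c12` gives 14200 nM

Compound 2 at 12100 nM belongs to the low end of these numbers. Two steps place it: a 1.2-fold higher number from compound 2 to compound 3 (0.07 log units; within the scatter) and a 2.1-fold lower number from compound 1 to compound 2 (0.32 log units; beyond the scatter) in turn. Compound 4 `Cc1nc2c3ccccc3ccc2c2nc3c(ccc4ccccc43)c(C)c12` has methyl in place of naphthalen-1-yl on an aromatic carbon on the shared core. The third step, a 1.8-fold lower number from compound 1 to compound 3 (0.25 log units; within the scatter), completes the evidence. All three steps are small, yet each swaps one aromatic group for another, so none shows what methyl does here. A small rise in this assay is therefore expected, with the estimated 1.7-fold higher number from compound 2 to compound 4 (0.22 log units; within the scatter) not clearly beyond the scatter. For compound 4 the estimate is 20000 nM within an expected range from 8000 nM to 45000 nM as its bounds.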

Compound 4, half-maximal inhibitory concentration: > 80000 nM
Compound 4: only a limit was reported; the forecaster's own chance of this, stated with the estimate: 10%; middle value at least 4.0-fold (0.60 log units) from the limit.
By their numbers in this assay, from the lowest: compounds 2, 3 and 1 (each within the scatter of the next, the first and the last beyond it). At a limit, above all of these: compound 4.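

In this assay compound 4, with methyl on this aromatic carbon, is reported only as a limit: the limit of > 80000 nM in this assay, at which 1 of the 4 values shown sits. Methyl gives a higher number than each aromatic group tried here: naphthalen-1-yl (an at least 6.6-fold higher number from compound 2 to compound 4 (0.82 log units; beyond the scatter)), 4-hydroxyphenyl (an at least 5.6-fold higher number from compound 3 to compound 4 (0.75 log units; beyond the scatter)) and 3-nitrophenyl (an at least 3.1-fold higher number from compound 1 to compound 4 (0.49 log units; beyond the scatter)). Swaps among those aromatic groups could not show this, since all of them keep an aromatic ring at the position opposite the ring nitrogen. The compounds shown leave open whether the aromatic ring matters or only a group larger than methyl. A longer chain or a cyclohexyl group at this position would separate the two.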